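A few compounds are considered here, and "the series" means these few. Any claim that something is new, unique, unknown or untested is made for them only; others in the source may bear on it.

Measured so far:

- compound 1, `COc1ccccc1NC(=O)c1nccc2ccccc12`: > 10000 nM
- compound 2, `O=C(Nc1cc(C(F)(F)F)cc(C(F)(F)F)c1)C1NCCc2ccccc21`: > 10000 nM
- compound 3, `COc1cccc(NC(=O)c2nccc3ccccc23)c1`: > 10000 nM

In a functional assay on NUGC-3 cells (Homo sapiens) for inhibition, read by sulforhodamine B assay, with a stated time of 48 h (on this read-out lower numbers stand for stronger inhibition of growth and higher numbers for weaker inhibition of growth), compound 3 gives > 10000 nM, which is a limit of the assay and not a measured number. Compound 1 likewise gives > 10000 nM, again a limit. Compound 2, built on a different core, gives > 10000 nM, also a limit. For the measured compounds named here, all three values therefore sit at the same place, (the limit of > 10000 nM in this assay, at which 3 of the 3 values shown sit), so no difference between any two of them can be read, and no step between measured compounds can be worked out.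

Compound 4, `O=C(Nc1cccc(O)c1)c1nccc2ccccc12`, is the next compound. It differs from compound 3 only in one place: hydrogen in place of methyl on an oxygen on an aromatic ring. With compound 3 at a limit, there is no number to move from, and the change is a small one. The step expected a step that the limit leaves unreadable from compound 3 to compound 4 is none beyond the usual scatter, and the most likely outcome is another limit. Compound 4 is accordingly expected to give about 20000 nM, with a range from 7000 nM to 60000 nM.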

Compound 4, concentration for 50% growth inhibition: > 10000 nM
Compound 4 gave a limit, no number; the forecaster's own chance of this, stated with the estimate: 85%; the middle value does not contradict the limit.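

No new step can be read, since compound 3 and compound 4 both give a limit and not a number: the limit of > 10000 nM in this assay, at which 4 of the 4 values shown sit.

The compounds shown leave open whether methoxy or hydroxy makes any difference to growth inhibition, and what a measurable value would look like.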